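Aminomethyl for Fluoro on a Kinase Inhibitor Benzamide

The compounds below may be only part of what the source reports. "The series", "measured", "known", "first", "only" and "open" are said of these compounds alone.

Among the three compounds measured in an assay on isolated protein for inhibition of Rho-associated protein kinase 2 (Homo sapiens), read by scintillation counting, radiometric assay and 33P incorporation, with a stated time of 40 min, in the presence of a further agent that is not named here (on this read-out higher numbers stand for weaker inhibition and lower numbers for stronger inhibition), compound 3 `O=C(COc1ccc2c(=O)ccoc2c1)Nc1cccc(NC(=O)c2ccc(F)cc2)c1` gives the lowest number, 54 nM. Compound 1 `CN(C)c1ccc(C(=O)Nc2cccc(NC(=O)COc3ccc4c(c3)NC(=O)CC4)c2)cc1` gives 3140 nM in this assay. Compound 2 `COc1ccc(OCC(=O)Nc2cccc(NC(=O)c3ccc(N(C)C)cc3)c2)cc1OC` reaches only a limit in this assay, > 10000 nM. For the measured compounds named here, the single step between compounds that differ in one place, an at least 3.1-fold higher number from compound 1 to compound 2 (0.50 log units; beyond the scatter), concerns the group on an oxygen on a saturated carbon and not the benzamide end, and its size is bounded by the limit of > 10000 nM in this assay, at which 1 of the 3 values shown sits. Compound 4 `NCc1ccc(C(=O)Nc2cccc(NC(=O)COc3ccc4c(=O)ccoc4c3)c2)cc1` differs from compound 3 by aminomethyl in place of fluoro on an aromatic carbon. Going by the values given here, no measured pair shows this change; compounds 1 and 3 differ in two places at once, so their values can be set side by side but not read as a step. Among the compounds with values here, with no direct precedent, the account expects the change to fall close to the scatter, with a slight lean toward a lower number: compound 4 is estimated at 40 nM, within 10 nM to 200 nM, which means an expected step of a 1.4-fold lower number from compound 3 to compound 4 (0.13 log units; within the scatter).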

Compound 4, half-maximal inhibitory concentration: 66 nM
Beside the measured number, compound 4's estimate is 1.7-fold (0.22 log units) below it; the range from low to high includes it.
By their numbers in this assay, from the lowest: compounds 3 and 4 (each within the scatter of the next); then compound 1. At a limit, above all of these: compound 2.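

With aminomethyl in place of fluoro on an aromatic carbon, para to a large group, this assay gives a 1.2-fold higher number from compound 3 to compound 4 (0.09 log units; within the scatter) and so shows that, on this core, either group at this position leaves the number within the scatter. For the compounds shown here, the earlier compounds could not show this: their one step concerned the group on an oxygen on a saturated carbon, and compound 1 and compound 3 differ in two places at once. Nothing given here speaks to why fluoro and aminomethyl read alike at this position.

What the compounds shown leave open is how a carboxylic acid, a hydroxymethyl group or a longer aminoethyl chain would read at this position in this assay. They also leave open whether aminomethyl and fluoro would read alike on the core of compound 1.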